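Shortening the side-chain amide in the cyclopropyl series

A few compounds are considered here, and "the series" means these few. Any claim that something is new, unique, unknown or untested is made for them only; others in the source may bear on it.

Measured so far:
Compound 1, `O=C(CN(c1nc(Cl)nc2[nH]cnc12)C1CC1)NCC(=O)OCc1ccccc1`: 18%
Compound 2, `O=C(CN(c1nc(Cl)nc2[nH]cnc12)C1CC1)N[C@@H](CCC(=O)OCc1ccccc1)C(=O)OCc1ccccc1`: 44.5%
Compound 3, `NC(=O)CC[C@H](NC(=O)CN(c1nc(Cl)nc2[nH]cnc12)C1CC1)C(=O)OCc1ccccc1`: 31.1%

All three numbers come from a functional assay on the whole organism (Tail, strain ICR) with Mus musculus as the target, in the tail flick test, with a stated time of 150 min, at a dose of 25 umol/kg by the oral route; on this read-out higher numbers stand for a stronger effect at the one dose given and lower numbers for a weaker effect. Compound 3 stands second of the three, above compound 1 and below compound 2. Compound 4, `NC(=O)C[C@H](NC(=O)CN(c1nc(Cl)nc2[nH]cnc12)C1CC1)C(=O)OCc1ccccc1`, is not yet measured; it differs from compound 3 by carbamoyl in place of carbamoylmethyl on a saturated chain carbon, two bonds along the chain from an amide-type nitrogen and a carbonyl carbon. Among the compounds with values here, no measured step shortens a side chain in this way. The nearest guides are the two additions onto compound 1, a number 13.1 percentage points higher from compound 1 to compound 3 (beyond the scatter) and a number 26.5 percentage points higher from compound 1 to compound 2 (beyond the scatter), where the longer chain brought the larger gain, and the terminal exchange a number 13.4 percentage points lower from compound 2 to compound 3 (beyond the scatter). Removing one carbon from the 2-carbamoylethyl chain is therefore expected to cost a little: a number 4.1 percentage points lower from compound 3 to compound 4 (within the scatter). Compound 4 is estimated at 27%, with a range of 15% to 40%.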

Compound 4, a percentage reported as activity, at one dose (the size of the read-out at that dose, not a potency): 13.5%
Estimate against measurement, compound 4: 13.5 percentage points above; measured number below the stated range.
By their numbers in this assay, from the lowest: compounds 4 and 1 (each within the scatter of the next); then compound 3; then compound 2.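

Carbamoylmethyl in place of hydrogen on the chain carbon brings no gain (a number 4.5 percentage points lower from compound 1 to compound 4 (within the scatter)), so a side chain at this position does not raise the effect in itself. Length counts here: the change from 2-carbamoylethyl to carbamoylmethyl removes the gain (a number 17.6 percentage points lower from compound 3 to compound 4 (beyond the scatter)). The gap is larger still for carbamoyl in place of (benzyloxycarbonyl)methyl (a number 31 percentage points lower from compound 2 to compound 4 (beyond the scatter)).

No measurement at hand explains this loss. Open, going by these compounds, is whether a longer chain ending in carbamoyl, or a carboxylic acid at the chain end, holds or raises the effect.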